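A few compounds are considered here, and "the series" means these few. Any claim that something is new, unique, unknown or untested is made for them only; others in the source may bear on it.

Three compounds of a shared core have been characterised in an ADME assay on microsomes from liver (Homo sapiens) for metabolic stability, using NADPH, with a stated time of 40 min, tested at 2 uM; a higher number here means that the compound lasts longer, a lower number that the compound disappears faster. Compound 1 `Cc1cccc2ccc(-c3c[nH]c4c(C)cccc34)nc12` gives 1.62 h. Compound 2 `Clc1cc(Cl)c2[nH]cc(-c3ccc4ccccc4n3)c2c1` gives 2.57 h, and compound 3 `Cc1cc(Cl)c2[nH]cc(-c3ccc4ccccc4n3)c2c1` gives 0.3 h. The step of an 8.6-fold higher number from compound 3 to compound 2 (0.93 log units; beyond the scatter) arises from chloro in place of methyl on an aromatic carbon. Compound 1 and compound 3 share the same kind of core, but the difference between the two cores is not broken down here.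

Compound 4 `Cc1cccc2c(-c3ccc4cccc(Cl)c4n3)c[nH]c12` has not yet been measured in this assay. It differs from compound 1 by chloro in place of methyl on an aromatic carbon. This is the same kind of change as that from compound 3 to compound 2, though the surroundings differ: in compound 2 the chloro enters meta to a chloro group, meta to a fused ring and para to a fused ring, whereas in compound 4 it enters ortho to a fused ring and meta to a fused ring. Going by the values given here, because the single observed instance of this change gave an 8.6-fold higher number from compound 3 to compound 2 (0.93 log units; beyond the scatter), and because compound 1 stands at 1.62 h, compound 4 is expected to show a step of a 2.2-fold higher number from compound 1 to compound 4 (0.33 log units; beyond the scatter), tempered by the different placement. Compound 4 is therefore estimated at 3.5 h, expected to fall between 1.3 h and 9 h.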

Compound 4, half-life: 1.75 h
Beside the measured number, compound 4's estimate is 2.0-fold (0.30 log units) above it; low and high end bracket the measured number.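

In this assay, the latest instance of chloro in place of methyl on an aromatic carbon gives a 1.1-fold higher number from compound 1 to compound 4 (0.03 log units; within the scatter), so here the change leaves the half-life within the scatter. Set beside the earlier instance, the change does not carry over at the same size from one core to the other: the same change on two cores in this assay, an 8.6-fold higher number (0.93 log units; beyond the scatter) from compound 3 to compound 2 and a 1.1-fold higher number (0.03 log units; within the scatter) from compound 1 to compound 4, 7.9-fold (0.90 log units) apart, beyond the scatter of two such steps. These two instances show that the size of the step is not constant in this series, but they do not show whether the core or the placement of the chloro accounts for the gap, nor what the change would do on any further core.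

The compounds shown carry only methyl and chloro as substituents on the shared core, so it remains open how the half-life would respond to other groups, such as a methoxy group, a nitrile or an amine. Also open, from the compounds shown here alone, is whether the chloro would give a large step or none at other places on the core of compound 1.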